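A few compounds are considered here, and "the series" means these few. Any claim that something is new, unique, unknown or untested is made for them only; others in the source may bear on it.

Of the compounds shown here, two from this series have been measured so far. Compound 2 `COc1cc(NC(C)CCCNC(=O)N(C2CCCCC2)C2CCCCC2)c2ncccc2c1` carries two cyclohexyl groups on the same amide-type nitrogen, and in a functional assay on MCF7 cells (Homo sapiens), read by MTT assay, with a stated time of 72 h (a lower number here means a stronger inhibitor, a higher number a weaker inhibitor), compound 2 gives 9000 nM. Among the measured compounds shown here, compound 1 `COc1cc(NC(C)CCCNC(=O)NCC2CCCCC2)c2ncccc2c1` carries only one group on that nitrogen, and in this assay compound 1 gives 61000 nM. Of the two, compound 2 stands at the lower number, and its gap to compound 1 lies beyond the usual scatter. Compound 3 `COc1cc(NC(C)CCCNC(=O)NC2CCCCC2)c2ncccc2c1` has not yet been measured. Its change from compound 2 is hydrogen in place of cyclohexyl on an amide-type nitrogen. Compound 1 also has one group on that nitrogen and gives the higher number 61000 nM, so the loss of one cyclohexyl is expected to weaken inhibition. The step of a 3.9-fold higher number from compound 2 to compound 3 (0.59 log units; beyond the scatter) is expected to be upward and beyond the scatter. In this assay compound 3 is estimated at 35000 nM, within a range from 12000 nM to 90000 nM.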

Compound 3, half-maximal inhibitory concentration: 41000 nM
For compound 3 the middle estimate is 1.2-fold (0.07 log units) below the measured one, within the range that was stated.
By their numbers in this assay, from the lowest: compound 2; then compounds 3 and 1 (each within the scatter of the next).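

In this assay the swap of one cyclohexyl for hydrogen on the amide-type nitrogen gives a 4.6-fold higher number from compound 2 to compound 3 (0.66 log units; beyond the scatter) and isolates a single change, which the earlier pair, differing in more than one way, could not do. Among the compounds shown here, with only one group on that nitrogen, cyclohexyl in place of cyclohexylmethyl gives a 1.5-fold lower number from compound 1 to compound 3 (0.17 log units; within the scatter) and stays within the scatter, so these two groups cannot be told apart here. Nothing available explains why the second cyclohexyl goes with the lower number.

As far as these compounds go, whether a methyl or a phenyl ring in place of the second cyclohexyl would keep the number near that of compound 2 remains open. So does the effect of an amine or a carboxylic acid attached to the cyclohexyl ring.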